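The source may report more compounds than this note shows. Statements on the series, on what has been measured and on what is new or still open speak of the compounds shown alone.

The measured compounds:
compound 1, `COc1ccc2c(-c3cc(C(F)(F)F)c(C#N)c(-c4cn(S(=O)(=O)c5ccc(C)cc5)c5cc(OC)ccc45)n3)cn(S(=O)(=O)c3ccc(C)cc3)c2c1`: 26.7%
compound 2, `COc1ccc2c(c1)c(-c1cc(C(F)(F)F)ccn1)cn2S(=O)(=O)c1ccc(C)cc1`: 23.2%
compound 3, `Cc1ccc(S(=O)(=O)n2cc(-c3cc(C(F)(F)F)c(C#N)c(-c4cn(S(=O)(=O)c5ccc(C)cc5)c5cc(Br)ccc45)n3)c3ccc(Br)cc32)cc1`: 18.8%

All three numbers come from a functional assay on A549 cells (Homo sapiens) for inhibition, tested at 1 uM; on this read-out lower numbers stand for a weaker effect and higher numbers for a stronger effect at the one concentration tested. Compound 2 has a number that falls between those of compound 1 and compound 3, and both gaps lie within the usual scatter of repeated measurements, so the three compounds cannot be told apart on these numbers. Compound 4, `Cc1ccc(S(=O)(=O)n2cc(-c3cc(C(F)(F)F)ccn3)c3cc(Br)ccc32)cc1`, has not yet been measured. Compared with compound 2 the change is bromo in place of methoxy on an aromatic carbon: methoxy leaves and bromo enters, on an aromatic carbon of a six-membered aromatic ring of carbon only, part of a fused or bridged system of two rings. Going by the values given here, no pair of measured compounds differs in exactly one place, so there is no measured step to lean on; the numbers of compound 1 and compound 3 lie within the scatter of each other, and compound 2 sits among them. Because compound 2 gives 23.2% and nothing in the set points to a shift, the step of a number 2.2 percentage points lower from compound 2 to compound 4 (within the scatter) is expected to be none beyond the scatter. Compound 4 is therefore estimated at 21%, with a range from 9% to 33%.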

Compound 4, a percentage reported as inhibition, at one concentration (the size of the read-out at that concentration, not a potency): 32.8%
Compound 4: the middle estimate sits 11.8 percentage points below what was measured; measured number inside the range.
By their numbers in this assay, from the lowest: compounds 3, 2, 1 and 4 (each within the scatter of the next, the first and the last beyond it).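

In this assay, going by these compounds alone, bromo in place of methoxy on an aromatic carbon gives the first step in this set that can be read at a single place: a number 9.6 percentage points higher from compound 2 to compound 4 (within the scatter). The position, on a six-membered aromatic ring of carbon only, part of a fused or bridged system of two rings, therefore carries either group with no difference that can be told from the usual scatter, at the one concentration tested. Nothing measured here bears on the reason for this result.

From the compounds shown here alone, whether a quite different group at the same carbon, such as an amine, a carboxylic acid or a longer alkoxy chain, would give a step beyond the scatter remains open. A single concentration also leaves open how the potencies of compound 2 and compound 4 compare.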